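Cytotoxicity in Raji cells: a larger aryl piece on compound 3

A few compounds are considered here, and "the series" means these few. Any claim that something is new, unique, unknown or untested is made for them only; others in the source may bear on it.

Of the compounds shown here, three have so far been tested in an ADME assay on Raji cells (Homo sapiens) for cytotoxicity, read by CellTiter-Glo and resazurin assay, with a stated time of 72 h; on this read-out higher numbers stand for an effect only at larger amounts of compound and lower numbers for an effect already at smaller amounts. Compound 1 `CC(C)N(Cc1cccc(OCCCCCC(=O)O)c1)C(=O)c1ccccc1` is the smallest of them. In this assay compound 1 reaches only a limit, > 26000 nM. Compound 2 `CC(C)N(Cc1cccc(OCCCCCC(=O)O)c1)C(=O)c1ccc(-c2ccc3c(c2)OCCO3)cc1` carries an extra ring system. In this assay compound 2 likewise stops at a limit, > 21900 nM. Compound 3 `CCOC(=O)CCCCCOc1cccc(CN(C(=O)c2ccccc2)C(C)C)c1` is the ethyl ester of compound 1. In this assay compound 3 again gives only a limit, > 26000 nM, so it stands among the inactive values, with no number of its own.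

The steps measured so far tell little: a step that the two limits leave unreadable from compound 1 to compound 2 and a step that the two limits leave unreadable from compound 1 to compound 3, since their values sit at the limit of > 21900 nM in this assay, at which 1 of the 3 values shown sits, and (the limit of > 26000 nM in this assay, at which 2 of the 3 values shown sit).

Compound 4 `CCOC(=O)CCCCCOc1cccc(CN(C(=O)c2ccc(-c3cccc(OC(C)C)c3)cc2)C(C)C)c1` differs from compound 3 by 3-isopropoxyphenyl in place of hydrogen on an aromatic carbon. For the measured compounds named here, no measured step touches the ring system that enters, and the step toward compound 2, which also adds a ring system, is unreadable. Compound 4 is therefore expected to remain without a measurable effect, an estimated step that the limit leaves unreadable from compound 3 to compound 4. The estimate for compound 4 is 30000 nM, with a range from 12000 nM to 100000 nM.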

Compound 4, half-maximal effective concentration: > 26000 nM
Compound 4 was reported as a limit; the forecaster's own chance of this, stated with the estimate: 75%; the middle value does not contradict the limit.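

Compound 3 and compound 4 both end at a limit rather than a number, so the step between them cannot be read. The compounds shown leave open at what amount, if any, any of these four compounds would harm the cells.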